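The compounds below may be only part of what the source reports. "The series", "measured", "known", "first", "only" and "open" are said of these compounds alone.

Measured so far:
- Compound 1 `FC(F)(F)c1ccc(CSc2nc(Nc3ccccc3C(F)(F)F)c3ccccc3n2)cc1`: in a functional assay on PC-3 cells (Homo sapiens) for cytotoxicity, read by MTT assay, with a stated time of 72 h (on this read-out lower numbers stand for stronger inhibition and higher numbers for weaker inhibition), compound 1 gives 34800 nM
- Compound 2 `COc1ccccc1Nc1nc(SCc2ccc(C(F)(F)F)cc2)nc2ccccc12`: in this assay compound 2 gives 14100 nM

Among the measured compounds shown here, compound 2 stands at the lowest of the two numbers known, and the only measured step so far is a 2.5-fold lower number from compound 1 to compound 2 (0.39 log units; beyond the scatter), which came with methoxy in place of trifluoromethyl on an aromatic carbon. Compound 3 `CCOc1ccccc1Nc1nc(SCc2ccc(C(F)(F)F)cc2)nc2ccccc12` has not yet been measured. It differs from compound 2 by methyl in place of hydrogen on a saturated chain carbon bound to an oxygen on an aromatic ring, so the methoxy of compound 2 becomes an ethoxy while everything else stays the same.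

For the measured compounds named here, the one measured step bears on this change only loosely: it exchanged a whole group at this position, whereas the move to compound 3 merely lengthens the chain that already sits there by one carbon. Nothing measured tells how such a lengthening acts here, so no step beyond the usual scatter is expected in either direction. Compound 3 is therefore estimated to give about 14000 nM in this assay, within a range from 6000 nM to 35000 nM. The step this estimate implies is a 1.0-fold lower number from compound 2 to compound 3 (0.00 log units; within the scatter), which is expected to stay within the scatter.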

Compound 3, half-maximal inhibitory concentration: 26200 nM
Estimate against measurement, compound 3: 1.9-fold (0.27 log units) below; low and high end bracket the measured number.
By their numbers in this assay, from the lowest: compounds 2, 3 and 1 (each within the scatter of the next, the first and the last beyond it).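

In this assay, lengthening methoxy to ethoxy gives a 1.9-fold higher number from compound 2 to compound 3 (0.27 log units; within the scatter), so one added methyl on this saturated chain carbon bound to an oxygen on an aromatic ring does not clearly separate the two compounds. Ethoxy in place of trifluoromethyl gives a 1.3-fold lower number from compound 1 to compound 3 (0.12 log units; within the scatter), so that pair cannot be told apart either, even though methoxy in place of trifluoromethyl gave a 2.5-fold lower number from compound 1 to compound 2 (0.39 log units; beyond the scatter), a step beyond the scatter; the ethoxy compound therefore lies within the scatter of both neighbours, and the separation seen with methoxy is not shown to carry over to the group one carbon longer. No measurement available here accounts for these numbers, so the result can be described but not explained.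

As far as these compounds go, whether a longer chain such as propoxy, or a hydroxyl or an amine in this same place on the aromatic ring, would shift the number beyond the scatter remains open. The three compounds also say nothing about how changes elsewhere on the shared core would act in this assay.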